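Rat plasma stability of a benzoyl-to-pyridinylcarbonyl exchange

The source may hold more compounds than are shown below. What is called first, only, known or untested is meant among the compounds shown, and "the series" means these compounds.

In an ADME assay on a cell-free system (plasma, Homo sapiens) for metabolic stability, with Plasma (Rattus norvegicus) as the target, read by HPLC, at pH 7.4 (a lower number here means that the compound disappears faster, a higher number that the compound lasts longer), compound 1 `CC(=O)Oc1ccccc1C(=O)O[C@H]1CO[C@H]2[C@@H]1OC[C@H]2OC(=O)c1ccccc1` gives 0.0107 h, the lowest of the three numbers recorded so far. Compound 2 `CC(=O)Oc1ccccc1C(=O)O[C@H]1CO[C@H]2[C@@H]1OC[C@H]2OC(=O)c1cccc(C)c1` gives 0.0203 h in this assay, and compound 3 `CC(=O)Nc1cccc(C(=O)O[C@@H]2CO[C@H]3[C@@H]2OC[C@@H]3OC(=O)c2ccccc2OC(C)=O)c1` gives 0.0583 h. The step of a 1.9-fold higher number from compound 1 to compound 2 (0.28 log units; within the scatter) adds a methyl on the aromatic ring of the benzoyl group, while the step of a 5.4-fold higher number from compound 1 to compound 3 (0.74 log units; beyond the scatter) puts an acetamido at that ring in place of hydrogen; the step of a 2.9-fold higher number from compound 2 to compound 3 (0.46 log units; beyond the scatter) links the two substituted analogues.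

Compound 4 `CC(=O)Oc1ccccc1C(=O)O[C@H]1CO[C@H]2[C@@H]1OC[C@H]2OC(=O)c1ccncc1` differs from compound 1 in a single place: pyridin-4-yl in place of phenyl on a carbonyl carbon. Among the compounds with values here, no measured step exchanges the aromatic ring itself; the two that bear on the same ring, from compound 1 to compound 2 and from compound 1 to compound 3, altered its substitution and moved the half-life upward by a small to modest amount. On that basis the expected step of a 1.9-fold higher number from compound 1 to compound 4 (0.27 log units; within the scatter) is taken as small, leaning upward but plausibly within the scatter. Compound 4 is therefore expected to give about 0.02 h in this assay, with a range of 0.007 h to 0.06 h.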

Compound 4, half-life: 0.0055 h
Compound 4: the middle estimate sits 3.6-fold (0.56 log units) above what was measured, and the stated range ends above it.
By their numbers in this assay, from the lowest: compounds 4, 1 and 2 (each within the scatter of the next, the first and the last beyond it); then compound 3.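

In this assay, within the data shown here, the exchange of the aromatic ring itself on this carbonyl carbon, a kind of change that no earlier step covered, gives a 1.9-fold lower number from compound 1 to compound 4 (0.29 log units; within the scatter), so this read-out does not separate pyridin-4-yl from phenyl at this position. Among these compounds, the substituted phenyl groups do separate from pyridin-4-yl, with a 3.7-fold lower number from compound 2 to compound 4 (0.57 log units; beyond the scatter) and an 11-fold lower number from compound 3 to compound 4 (1.03 log units; beyond the scatter), which leaves the 3-acetamidophenyl group of compound 3 as the only group here that lies beyond the scatter of both phenyl and pyridin-4-yl. Nothing available on these compounds bears on why the numbers fall this way.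

The compounds shown leave open whether an acetamido group on the pyridin-4-yl ring would raise the half-life as it does on the phenyl ring. They also do not tell how pyridin-3-yl or pyridin-2-yl would compare at this carbonyl carbon, or what an amine or a carboxylic acid on the ring would do to the number.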